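Trimming the Chain Bound to the Aromatic Nitrogen

The source may hold more compounds than are shown below. What is called first, only, known or untested is meant among the compounds shown, and "the series" means these compounds.

In a functional assay on FaDu cells (Homo sapiens) for cytotoxicity, read by MTT assay, with a stated time of 72 h (on this read-out lower numbers stand for higher toxicity in this test and higher numbers for lower toxicity in this test), compound 3 `COCC(C)n1cc(C(=O)C(=O)Nc2ccc(OC)nc2)c2ccccc21` gives 12 nM, the lowest of the two numbers obtained so far. Compound 2 `COc1ccc(NC(=O)C(=O)c2cn(C(C)C)c3ccccc23)cn1` gives 85 nM. Compound 1 `CCn1cc(C(=O)C(=O)Nc2ccncc2)c2ccccc21` reaches only the limit > 10000 nM, which is not a number. For the measured compounds named here, the single measured step with one change is a 7.1-fold lower number from compound 2 to compound 3 (0.85 log units; beyond the scatter); the methoxy that enters there sits on the very chain that compound 4 now loses.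

Compound 4 `CCn1cc(C(=O)C(=O)Nc2ccc(OC)nc2)c2ccccc21` differs from compound 3 by hydrogen in place of methoxymethyl on a saturated chain carbon bound to an aromatic nitrogen and a saturated chain carbon. This undoes the gain seen on the way to compound 3 and shortens the chain further, to ethyl, the same chain that compound 1 carries at this place. Going by the values given here, compound 1 and compound 4 differ also in the amide part, so no single step joins them; compound 1 rests at the limit (the limit of > 10000 nM in this assay, at which 1 of the 3 values shown sits). The expectation is therefore a rise of at least the size of the measured step, and possibly more, so that a 13-fold higher number from compound 3 to compound 4 (1.10 log units; beyond the scatter) is the estimated step. Compound 4 is accordingly expected to give 150 nM, with a range from 40 nM to 600 nM.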

Compound 4, concentration lethal to 50% of the cells: 219 nM
For compound 4 the middle estimate is 1.5-fold (0.16 log units) below the measured one, within the range that was stated.
By their numbers in this assay, from the lowest: compound 3; then compound 2; then compound 4. At a limit, above all of these: compound 1.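

Compounds 4, 2 and 3 share the 6-methoxypyridin-3-yl amide part, so they can be read as a series at this one carbon in this assay: hydrogen in place of methyl gives a 2.6-fold higher number from compound 2 to compound 4 (0.41 log units; beyond the scatter), while hydrogen in place of methoxymethyl gives an 18-fold higher number from compound 3 to compound 4 (1.26 log units; beyond the scatter), and among these three, none goes against the trend that a larger group here comes with a lower number. Compound 4 also provides the first view of the amide part with the ethyl chain held constant, as 6-methoxypyridin-3-yl in place of pyridin-4-yl gives an at least 45-fold lower number from compound 1 to compound 4 (1.65 log units; beyond the scatter). The size of that step is only a bound, as compound 1 gives a limit rather than a number: the limit of > 10000 nM in this assay, at which 1 of the 4 values shown sits.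

From the compounds shown here alone, it remains open whether the gain at this carbon follows the oxygen of the methoxymethyl or simply the size of the chain, a question that a 1-methylpropyl chain, with a carbon in place of that oxygen, could help to answer. Going by these compounds, it is also open whether an amine at the end of this chain would fit the same trend, and whether the chain would have any effect on the pyridin-4-yl amide.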